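The source may hold more compounds than are shown below. What is called first, only, known or untested is meant among the compounds shown, and "the series" means these compounds.

Compound 1 `O=C(Nc1cccc(/C=C/C(=O)c2nc3ccccc3[nH]2)c1)c1ccccc1` gives 8340 nM in a functional assay on 143B cells (Homo sapiens) for antiproliferative activity, read by MTT assay, with a stated time of 48 h; on this read-out higher numbers stand for weaker inhibition and lower numbers for stronger inhibition. Compound 2 `O=C(Nc1cccc(/C=C/C(=O)c2nc3ccccc3[nH]2)c1)c1ccc(Br)cc1` gives 7310 nM in this assay, and compound 3 `O=C(Nc1cccc(/C=C/C(=O)c2nc3ccccc3[nH]2)c1)c1cc(Cl)cc(Cl)c1` gives 3660 nM in this assay. Among these three numbers compound 2 stands second highest: its nearest neighbour is compound 1, with a 1.1-fold lower number from compound 1 to compound 2 (0.06 log units; within the scatter), and its furthest is compound 3, with a 2.0-fold lower number from compound 2 to compound 3 (0.30 log units; within the scatter). For the measured compounds named here, the one step beyond the scatter is a 2.3-fold lower number from compound 1 to compound 3 (0.36 log units; beyond the scatter).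

Compound 4 `O=C(/C=C/c1cccc(NS(=O)(=O)c2cccc(Cl)c2)c1)c1nc2ccccc2[nH]1` differs from compound 2 in one place ((3-chlorophenyl)sulfonyl in place of (4-bromophenyl)carbonyl on a nitrogen on an aromatic ring). Going by the values given here, none of the measured steps touches this part of the molecule: all three vary only the substituents on the phenyl ring attached to the carbonyl carbon, and even there the largest change stays modest. Among the compounds with values here, no measured step therefore bears directly on the exchange of the carbonyl for the sulfonyl, and the expectation rests on the narrow spread of the three known values. On that basis compound 4 is expected to show a 1.0-fold lower number from compound 2 to compound 4 (0.02 log units; within the scatter), no step beyond the scatter in either direction. Compound 4 is estimated at 7000 nM, within a range from 2800 nM to 18000 nM.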

Compound 4, half-maximal inhibitory concentration: 2510 nM
The estimate for compound 4 lay 2.8-fold (0.45 log units) above the measured number; measured number below the stated range.
By their numbers in this assay, from the lowest: compounds 4, 3, 2 and 1 (each within the scatter of the next, the first and the last beyond it).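

For the compounds shown here, at this nitrogen on an aromatic ring, the carbonyl-linked group can give way to (3-chlorophenyl)sulfonyl with a shift in this assay that goes beyond the scatter against two of the earlier compounds, with a 2.9-fold lower number from compound 2 to compound 4 (0.46 log units; beyond the scatter) and a 3.3-fold lower number from compound 1 to compound 4 (0.52 log units; beyond the scatter). Against the dichlorinated amide the shift does not hold, with a 1.5-fold lower number from compound 3 to compound 4 (0.16 log units; within the scatter), so compound 4 and compound 3 cannot be told apart and the sulfonyl group offers no clear gain over the (3,5-dichlorophenyl)carbonyl group. Nothing among the data offers an explanation for these steps.

The linker and the ring substituents change together in every one of these steps, so the share of the sulfonyl itself remains unresolved. Also open, as far as these compounds go, is how a methylsulfonyl or an acetyl group on this nitrogen, without the aromatic ring, would read.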